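Replacing diethylcarbamoyl with 3-(piperidin-1-yl)propyl

A few compounds are considered here, and "the series" means these few. Any claim that something is new, unique, unknown or untested is made for them only; others in the source may bear on it.

Compound 1 `CSc1ccc(/C(=N\O)c2cccc3ccccc23)cc1` gives 18000 nM
Compound 2 `CCN(CC)C(=O)CO/N=C(\c1ccc(SC)cc1)c1cccc2ccccc12` gives 28000 nM
Compound 3 `CCCCC(CC)CNCCCO/N=C(\c1ccc(OC)cc1)c1cccc2ccccc12` gives > 50000 nM as a limit of the assay

These results come from a functional assay on MCF7 cells (Homo sapiens) for antiproliferative activity, read by MTT assay, with a stated time of 24 h (on this read-out lower numbers stand for an effect already at smaller amounts and higher numbers for an effect only at larger amounts of compound), and describe how much compound is needed for an effect on the cells. Among the compounds with values here, compound 2 and compound 1 lie within the usual scatter of each other, and they are the only two compounds with exact numbers. For compound 3 there is only the limit of > 50000 nM in this assay, at which 1 of the 3 values shown sits, and no exact number.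

Compound 4 `CSc1ccc(/C(=N\OCCCCN2CCCCC2)c2cccc3ccccc23)cc1` has not been measured yet. It differs from compound 2 in one group (3-(piperidin-1-yl)propyl in place of diethylcarbamoyl on a saturated chain carbon bound to an oxygen on an unsaturated carbon), and the rest of the structure stays the same. Within the data shown here, only one measured step concerns this part of the molecule: a 1.6-fold higher number from compound 1 to compound 2 (0.19 log units; within the scatter) when (diethylcarbamoyl)methyl took the place of hydrogen on an oxygen. That single step gives no reason to expect a large move in this assay, but it is thin ground, so the range is kept wide. The expected result is a 1.4-fold lower number from compound 2 to compound 4 (0.15 log units; within the scatter) and no clear change beyond the scatter is foreseen. Compound 4 is estimated at 20000 nM (expected range 6000 nM to 50000 nM).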

Compound 4, half-maximal effective concentration: 8000 nM
Estimate against measurement, compound 4: 2.5-fold (0.40 log units) above, and the stated range covers the measured number.
By their numbers in this assay, from the lowest: compound 4; then compounds 1 and 2 (each within the scatter of the next). At a limit, above all of these: compound 3.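

In this assay, this place on the oxygen proves sensitive to the attached group, which compound 1 and compound 2 alone could not show (a 3.5-fold lower number from compound 2 to compound 4 (0.54 log units; beyond the scatter)). The 4-(piperidin-1-yl)butyl group also separates from a bare hydrogen on the oxygen (a 2.3-fold lower number from compound 1 to compound 4 (0.35 log units; beyond the scatter)), whereas (diethylcarbamoyl)methyl stayed within the scatter of it (a 1.6-fold higher number from compound 1 to compound 2 (0.19 log units; within the scatter)). Nothing available here bears on why this exchange gives a lower number.

Still open, from the compounds shown here alone, is whether the change belongs to the piperidine ring, its nitrogen or the length of the chain that carries it. A shorter chain ending in the same piperidine, or the same butyl chain ending in a morpholine ring or an open-chain diethylamine, would begin to separate these parts.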